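Chloro on the Benzyl Arm of a Shared Core

A few compounds are considered here, and "the series" means these few. Any claim that something is new, unique, unknown or untested is made for them only; others in the source may bear on it.

Of the compounds shown here, two of one shared core have been measured so far. Going by the values given here, compound 1 `CC1=C(C(=O)Nc2ccc([N+](=O)[O-])cc2)C(c2ccc(Br)cc2)N=C(SCc2ccccc2Cl)N1` and compound 2 `CC1=C(C(=O)Nc2ccc([N+](=O)[O-])cc2)C(c2cccc([N+](=O)[O-])c2)N=C(SCc2ccccc2)N1` differ at two places, so no single step joins them, and their two values may only be set side by side. In a functional assay on the whole organism (artery, strain albino) with Rattus norvegicus as the target, with a stated time of 30 min, at a dose of 10 mg/kg by the oral route (a higher number here means more inhibition at the dose given (going by the name of the read-out), a lower number less inhibition), compound 1 gives 3.6%, while compound 2 gives 4.1%; the two numbers lie within the usual scatter of each other, so compound 2 stands alongside compound 1 rather than apart from it. Compound 3 `CC1=C(C(=O)Nc2ccc([N+](=O)[O-])cc2)C(c2cccc([N+](=O)[O-])c2)N=C(SCc2ccccc2Cl)N1` has not yet been measured. It differs from compound 2 in a single place: chloro in place of hydrogen on an aromatic carbon. Compound 1 already carries this same 2-chlorobenzyl group and gives a low number, so no step beyond the scatter is expected from compound 2 to compound 3. The estimated step of a number 0.4 percentage points higher from compound 2 to compound 3 (within the scatter) is therefore small. For compound 3 the expected value in this assay is 4.5%, in a range from 0% to 13%.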

Compound 3, a percentage reported as inhibition, in the whole organism at one dose (the size of the read-out at that dose, not a potency): 3.6%
Beside the measured number, compound 3's estimate is 0.9 percentage points above it, within the range that was stated.
By their numbers in this assay, from the lowest: compounds 1, 3 and 2 (each within the scatter of the next).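

Benzyl to 2-chlorobenzyl now gives the first single-place reading at this position: in this assay the change amounts to a number 0.5 percentage points lower from compound 2 to compound 3 (within the scatter), so chloro in place of hydrogen on this aromatic carbon leaves the number inside the scatter. The saturated ring carbon can be read as well, since with the 2-chlorobenzyl group held, 3-nitrophenyl in place of 4-bromophenyl gives no change at the digits printed from compound 1 to compound 3 (within the scatter), again no step beyond the scatter.

From the compounds shown here alone, whether an amine or a carboxylic acid on the benzyl ring would move the read-out beyond the scatter stays open. So does the effect of a longer chain between the sulfur and that ring. No supporting evidence accompanies these results, so no cause can be given for either step.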